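Chloro for methoxy in two isomeric quinolone cores

The source may report more compounds than this note shows. Statements on the series, on what has been measured and on what is new or still open speak of the compounds shown alone.

The study concerns two pairs of benzylquinolones that share a change of a single ring substituent. Compound 1 `COc1cccc2c(=O)c(Cc3ccccc3)c(C)[nH]c12` carries a methoxy group, and in a physicochemical assay for solubility, read by HPLC, at pH 7.4 (a lower number here means a less soluble compound, a higher number a more soluble compound), compound 1 gives > 20000 nM, which is a limit of the assay rather than a number. Its partner, compound 2 `Cc1[nH]c2c(Cl)cccc2c(=O)c1Cc1ccccc1`, bears a chloro instead, and in this assay compound 2 gives 5000 nM. The change between them is chloro in place of methoxy on an aromatic carbon, and it produced an at least 4.0-fold lower number from compound 1 to compound 2 (0.60 log units; beyond the scatter). Compound 3 `COc1cccc2[nH]c(C)c(Cc3ccccc3)c(=O)c12` has the same atoms as compound 1 joined differently; the difference between the two cores is not broken down here. In this assay compound 3 gives > 20000 nM, again a limit of the assay. Compound 4 `Cc1[nH]c2cccc(Cl)c2c(=O)c1Cc1ccccc1` remains to be measured in this assay, and it differs from compound 3 by chloro in place of methoxy on an aromatic carbon, the same change as in the first pair. Because compound 1 and compound 3 both sit at the limit of > 20000 nM in this assay, at which 2 of the 3 values shown sit, the starting point of the second step is known only as a limit. Compound 4 is expected to show a step of an at least 4.0-fold lower number from compound 3 to compound 4 (0.60 log units; beyond the scatter), resting on the measured step of an at least 4.0-fold lower number from compound 1 to compound 2 (0.60 log units; beyond the scatter). Compound 4 is therefore estimated at 5000 nM, roughly between 1500 nM and 20000 nM.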

Compound 4, solubility: 2000 nM
Compound 4: middle estimate off by 2.5-fold (0.40 log units), on the high side, and the stated range covers the measured number.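

In this assay, chloro in place of methoxy on an aromatic carbon gave a lower number in the second core, with an at least 10-fold lower number from compound 3 to compound 4 (1.00 log units; beyond the scatter), just as it did in the first core, with an at least 4.0-fold lower number from compound 1 to compound 2 (0.60 log units; beyond the scatter). Going by these compounds alone, the direction of the change therefore carried over between these two cores, although this rests on only two pairs. It does not show whether the size of the step carried over, and the two steps cannot be ranked against each other, because each starts from a limit and not from a number: the limit of > 20000 nM in this assay, at which 2 of the 4 values shown sit.

The compounds shown leave open whether the change would run the same way on other aromatic carbons of these cores, or in a core with a different group in place of the benzyl. They also leave open how an amine or a carboxylic acid in place of the methoxy would read in this assay.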